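The compounds below may be only part of what the source reports. "The series", "measured", "known", "first", "only" and "open" are said of these compounds alone.

The account follows a set of compounds sharing one core, assessed in an ADME assay on Vero cells (Chlorocebus sabaeus) for cytotoxicity, read by MTT assay, with a stated time of 48 h; a higher number here means a weaker inhibitor, a lower number a stronger inhibitor. Compound 1 `O=c1cc(NCc2cccc(F)c2)sc2c([N+](=O)[O-])cc(C(F)(F)F)cc12` carries a 3-fluorophenyl group on the chain that links to the ring nitrogen. In this assay compound 1 returns only a limit, > 64 ug/mL, so no number is known for it. Two other compounds with a different core were also tested: compound 2 `O=c1nc(NCC2CCCCC2)oc2c([N+](=O)[O-])cc(C(F)(F)F)cc12` gives 29.7 ug/mL in this assay, and compound 3 `CN(Cc1ccc2c(c1)OCCO2)c1nc(=O)c2cc(C(F)(F)F)cc([N+](=O)[O-])c2o1` gives 9.27 ug/mL in this assay. Compound 1 thus sits at the limit itself (the limit of > 64 ug/mL in this assay, at which 1 of the 3 values shown sits), at the weak end of what the assay reports.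

Compound 4 `O=c1cc(NCc2ccc3c(c2)OCCO3)sc2c([N+](=O)[O-])cc(C(F)(F)F)cc12` differs from compound 1 in one place: 2,3-dihydro-1,4-benzodioxin-6-yl in place of 3-fluorophenyl on a saturated chain carbon bound to a nitrogen on an aromatic ring. Going by the values given here, no measured pair shows this change directly. The expected step of an at least 1.2-fold lower number from compound 1 to compound 4 (0.10 log units; that floor lies within the scatter) is small, likely within the scatter, with a slight lean toward stronger inhibition. Compound 4 is therefore expected to give about 50 ug/mL in this assay, within a range from 20 ug/mL to 100 ug/mL.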

Compound 4, half-maximal inhibitory concentration: > 64 ug/mL
Compound 4 gave a limit, no number (the forecaster's own chance of this, stated with the estimate: 55%); at least 1.2-fold (0.10 log units) between middle value and limit.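

Compound 1 and compound 4 each return only a limit in this assay, so no step can be read between them: the limit of > 64 ug/mL in this assay, at which 2 of the 4 values shown sit.

The compounds shown leave open how large the change from 3-fluorophenyl to 2,3-dihydro-1,4-benzodioxin-6-yl is on the shared core, and in which direction it runs.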